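This account rests on a few compounds, and the source may have more. Where it says the series, first, only, none or still open, it means among the compounds named here.

In a functional assay on KB cells (Homo sapiens) for cytotoxicity (on this read-out lower numbers stand for stronger inhibition and higher numbers for weaker inhibition), compound 1 `Cc1ccccc1Cn1cc(C#N)c2c(N)ncnc21` gives > 100000 nM, which is a limit of the assay and not a number. Two other compounds do give numbers: compound 2 `CCOCn1cc(C(=N)S)c2c(N)ncnc21` reads 68000 nM, and compound 3 `Cc1cccc(Cn2cc(C(=N)S)c3c(N)ncnc32)c1` reads 30000 nM. Compound 3 therefore holds the lower of the two numbers, and its cytotoxicity, though the stronger of that pair, is still weak in absolute terms.

Compound 4 `Cc1ccccc1Cn1cc(C(=N)S)c2c(N)ncnc21` is made from the same atoms as compound 3, joined differently: 2-methylphenyl in place of 3-methylphenyl on a saturated chain carbon bound to an aromatic nitrogen. In plain words, 2-methylphenyl takes the place of 3-methylphenyl on a saturated chain carbon bound to an aromatic nitrogen.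

Among the measured compounds shown here, only one measured step bears on this change: a 2.3-fold lower number from compound 2 to compound 3 (0.36 log units; beyond the scatter). That modest step replaced ethoxy with 3-methylphenyl at this same place, so it shows that a change here can shift the number, but only slightly. For the measured compounds named here, no measurement yet shows what happens when 3-methylphenyl gives way to 2-methylphenyl, and this swap looks smaller than the one already measured. The expected result is therefore no shift beyond the scatter, in either direction, and the estimated step is no change at the digits printed from compound 3 to compound 4 (within the scatter).

For compound 4, the estimated value is 30000 nM, with an expected range from 12000 nM to 75000 nM.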

Compound 4, half-maximal inhibitory concentration: > 17000 nM
Compound 4 gave a limit, no number (the forecaster's own chance of this, stated with the estimate: 10%); the middle value is on the limit's open side.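

In this assay compound 4 gives > 17000 nM, which is a limit and not a number. The steps to compound 4 from compound 1, compound 2 and compound 3 cannot be read. The compounds shown leave open whether 2-methylphenyl in place of 3-methylphenyl on a saturated chain carbon bound to an aromatic nitrogen shifts the cytotoxicity at all, and in which direction.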